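The source may hold more compounds than are shown below. What is called first, only, known or untested is meant among the compounds shown, and "the series" means these compounds.

Working notes on the series. Compound 1 `c1ccc(C(/N=C2\CCCCCN2)C2CC2)cc1`, compound 2 `c1ccc(C(/N=C2\CCCCCCN2)C2CC2)cc1` and compound 3 `c1ccc(C(/N=C2\CCCCCN2)c2ccco2)cc1` have been run in a functional assay on the whole organism (plasma, strain Sprague-Dawley) with Rattus norvegicus as the target, with a stated time of 2 h, at a dose of 100 mg/kg by the oral route; a lower number here means a weaker effect, a higher number a stronger effect of the compound at the dose given. In this assay compound 1 gives 51%, compound 2 gives 58% and compound 3 gives 52%; all three numbers lie within the scatter of one another, so no order among them is read. Compound 3 differs from compound 1 by furan-2-yl in place of cyclopropyl on a saturated chain carbon bound to an aromatic carbon and a double-bonded nitrogen, and this change made a step of a number 1 percentage points higher from compound 1 to compound 3 (within the scatter). How the core of compound 2 differs from the core of compound 1 is not broken down here.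

Compound 4 `c1ccc(C(/N=C2\CCCCCCN2)c2ccco2)cc1` has not yet been measured in this assay. It differs from compound 2 by furan-2-yl in place of cyclopropyl on a saturated chain carbon bound to an aromatic carbon and a double-bonded nitrogen, the same change already seen between compound 1 and compound 3, at the same place in both pairs. Because the earlier step was a number 1 percentage points higher from compound 1 to compound 3 (within the scatter), the expected step from compound 2 to compound 4 is a number 1 percentage points higher from compound 2 to compound 4 (within the scatter), set beside that earlier one and resting on it alone. On this basis compound 4 is estimated to give 59% in this assay, with an expected range from 45% to 72%.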

Compound 4, a percentage reported as inhibition, in the whole organism at one dose (the size of the read-out at that dose, not a potency): 61%
Estimate against measurement, compound 4: 2 percentage points below; the measured number falls inside the stated range.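

On the second core, in this assay, furan-2-yl in place of cyclopropyl made a step of a number 3 percentage points higher from compound 2 to compound 4 (within the scatter). Set together, the two steps show that this change behaves alike on the two cores, with no difference that can be read between them: the same change on two cores in this assay, a number 1 percentage points higher (within the scatter) from compound 1 to compound 3 and a number 3 percentage points higher (within the scatter) from compound 2 to compound 4, 2 percentage points apart, within the scatter of two such steps. This does not show that the change raises the read-out on either core, since each step lies within the scatter, and two cores give no rule for any other core in the series, nor does a read-out at one dose give a potency.

The compounds shown leave open what other groups would do on the saturated chain carbon bound to an aromatic carbon and a double-bonded nitrogen, for instance an amine, a carboxylic acid or a longer chain, and whether any of them would give a step beyond the scatter. On these data alone, only cyclopropyl and furan-2-yl are compared there, so any wider reading of that place remains untested in these notes.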